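Phenoxy to ethoxy: what happens without the ring?

The compounds below may be only part of what the source reports. "The series", "measured", "known", "first", "only" and "open" are said of these compounds alone.

Compound 1 `CC(Nc1ccccc1Oc1cccc(F)c1)=C1C(=O)CC(c2ccccc2)CC1=O`: 170 nM
Compound 2 `CC(Nc1ccccc1Oc1ccc(Cl)cc1)=C1C(=O)CC(c2ccccc2)CC1=O`: 190 nM
Compound 3 `CC(Nc1ccccc1Oc1ccccc1)=C1C(=O)CC(c2ccccc2)CC1=O`: 170 nM

All three values come from a functional assay on CCRF-CEM cells (Homo sapiens) for antiproliferative activity, read by cell counting, with a stated time of 96 h; on this read-out lower numbers stand for stronger inhibition and higher numbers for weaker inhibition. Compound 3, at 170 nM, lies within the scatter of both other compounds, so it holds no rank among them.

Compound 4 `CCOc1ccccc1NC(C)=C1C(=O)CC(c2ccccc2)CC1=O` differs from compound 3 in one place, with phenoxy giving way to ethoxy: ethyl in place of phenyl on an oxygen on an aromatic ring.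

The measured steps that bear on this all concern the phenyl that leaves. Hydrogen in place of fluoro gave no change at the digits printed from compound 1 to compound 3 (within the scatter), hydrogen in place of chloro gave a 1.1-fold lower number from compound 2 to compound 3 (0.05 log units; within the scatter), and 4-chlorophenyl in place of 3-fluorophenyl gave a 1.1-fold higher number from compound 1 to compound 2 (0.05 log units; within the scatter). Among the compounds with values here, each of these steps keeps the ring, and no measured compound lacks it, so they cannot size the present change directly. Replacing the whole phenyl is a larger edit than any of them, so a moderate move towards a higher number in this assay, meaning weaker inhibition, is expected, with wide uncertainty.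

That expectation amounts to a 2.4-fold higher number from compound 3 to compound 4 (0.37 log units; beyond the scatter). For compound 4 the estimate is 400 nM, with an expected range of 120 nM to 1500 nM.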

Compound 4, half-maximal inhibitory concentration: 190 nM
Estimate against measurement, compound 4: 2.1-fold (0.32 log units) above; low and high end bracket the measured number.
By their numbers in this assay, from the lowest: compounds 1, 3, 2 and 4 (each within the scatter of the next).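

In this assay the ring on this oxygen is not needed to keep the number where it stands: ethyl in place of phenyl gives a 1.1-fold higher number from compound 3 to compound 4 (0.05 log units; within the scatter) even though a six-membered aromatic ring of 6 heavy atoms leaves and only 2 heavy atoms enter. Within the data shown here, the same reading holds against the halogen-bearing rings, with ethyl in place of 4-chlorophenyl giving no change at the digits printed from compound 2 to compound 4 (within the scatter) and ethyl in place of 3-fluorophenyl giving a 1.1-fold higher number from compound 1 to compound 4 (0.05 log units; within the scatter) so that all four compounds stand together within the scatter, something the earlier compounds could not show while each of them kept a ring here. Nothing measured here says why this group can shrink so far without a visible cost.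

The compounds shown carry only substituted or plain phenyl and ethyl on this oxygen. Going by these compounds, how far this tolerance reaches remains open, whether to a methyl or a bare hydroxyl, or to a longer chain such as butyl or one ending in an amine or a carboxylic acid. On these data alone, all four also share the rest of the core, so whether the same freedom holds with a different group elsewhere is still unknown.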